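The source may hold more compounds than are shown below. What is called first, only, known or untested is meant among the compounds shown, and "the series" means these compounds.

Compound 1 `CCOC(=O)c1cc(-c2cccc(OCc3cccc([N+](=O)[O-])c3)c2)on1`. In an ADME assay on Vero cells (Chlorocebus sabaeus) for cytotoxicity, with a stated time of 72 h (a lower number here means a stronger inhibitor, a higher number a weaker inhibitor), compound 1 reaches only the assay limit > 128000 nM.
Compound 2 `CCOC(=O)c1cc(-c2cccc(OCc3cccc(C)c3)c2)on1`. In this assay compound 2 likewise reaches only the limit > 128000 nM.

Compound 2 therefore stands at the limit of this assay, with no number behind it. Going by the values given here, the one measured step, from compound 1 to compound 2 a step that the two limits leave unreadable from compound 1 to compound 2, cannot be sized because both of its values sit at the limit of > 128000 nM in this assay, at which 2 of the 2 values shown sit. Compound 3 `CCOC(=O)c1cc(-c2cccc(OCc3ccccc3Cl)c2)on1` differs from compound 2 by 2-chlorophenyl in place of 3-methylphenyl on a saturated chain carbon bound to an oxygen on an aromatic ring. Among the compounds with values here, no measured step gives a readable size for a change at this position, so nothing beyond the scatter is expected for the step from compound 2 to compound 3 a step that the limit leaves unreadable from compound 2 to compound 3. Compound 3 is expected to sit at 150000 nM in this assay, with a range from 60000 nM to 400000 nM, most likely reported again as a limit.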

Compound 3, half-maximal inhibitory concentration: > 128000 nM
Compound 3 ended at the assay's limit (the forecaster's own chance of this, stated with the estimate: 85%); the middle value lies beyond the limit too.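

Going by these compounds alone, no step among compound 1, compound 2 and compound 3 can be read in this assay, because all three values are limits: the limit of > 128000 nM in this assay, at which 3 of the 3 values shown sit.
The compounds shown leave open whether 3-nitrophenyl, 3-methylphenyl and 2-chlorophenyl differ at all in this assay, and which change at this position would bring a readable value.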